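The compounds below may be only part of what the source reports. "The series", "measured", "known", "first", "only" and "open" are said of these compounds alone.

Compound 1 `c1ccc(-c2nnc(-c3ccc(-n4cccc4)cc3)o2)cc1` and compound 2 `O=C(NNC(=O)c1ccc(-n2cccc2)cc1)c1ccccc1` share a pyrrole-bearing phenyl group but differ in the part that links it to the second benzene; how the two cores differ is not broken down here. In an ADME assay on A549 cells (Homo sapiens) for cytotoxicity, read by MTT assay, with a stated time of 72 h (a higher number here means a weaker inhibitor, a lower number a stronger inhibitor), compound 1 gives 256000 nM and compound 2 gives 215000 nM, two numbers that lie within the scatter of each other. Compound 3 `O=[N+]([O-])c1cccc(-c2nnc(-c3ccc(-n4cccc4)cc3)o2)c1` carries one extra group relative to compound 1: nitro in place of hydrogen on an aromatic carbon. That addition moved the result no change at the digits printed from compound 1 to compound 3 (within the scatter), and compound 3 gives 256000 nM in this assay. Compound 4 `O=C(NNC(=O)c1ccc([N+](=O)[O-])cc1)c1ccc(-n2cccc2)cc1`, not yet measured, is built from compound 2 by the same kind of change: nitro in place of hydrogen on an aromatic carbon. The surroundings differ, though: in compound 3 the nitro sits meta to a large group, in compound 4 it sits para to a large group. Because the step of no change at the digits printed from compound 1 to compound 3 (within the scatter) stayed flat, the step from compound 2 to compound 4 is expected to be about no change at the digits printed from compound 2 to compound 4 (within the scatter). Compound 4 is therefore estimated at 215000 nM, with an expected range from 110000 nM to 430000 nM.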

Compound 4, half-maximal inhibitory concentration: 198000 nM
Compound 4: the middle estimate sits 1.1-fold (0.04 log units) above what was measured; the measured number falls inside the stated range.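

In this assay, the new comparison gives a 1.1-fold lower number from compound 2 to compound 4 (0.04 log units; within the scatter), so on this core too, nitro in place of hydrogen leaves a number that cannot be told apart from that of the parent compound. Set beside the earlier step, the same change reads alike on the two cores: the same change on two cores in this assay, no change at the digits printed (within the scatter) from compound 1 to compound 3 and a 1.1-fold lower number (0.04 log units; within the scatter) from compound 2 to compound 4, 1.1-fold (0.04 log units) apart, within the scatter of two such steps

This shows that a flat result carried over between these two cores, but both steps are flat, so it does not show that a change with a clear effect would carry over in the same way, and two cores are too few to speak for the whole series; the nitro in compound 4 also sits para to a large group and stands elsewhere in compound 3, so core and position are not separated.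

As far as these compounds go, whether an amine, a carboxylic acid or a longer chain on the same ring would also leave the number flat stays open. So does whether the nitro step would read the same way on other cells.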